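The source may hold more compounds than are shown below. What is called first, only, known or untested is meant among the compounds shown, and "the series" means these compounds.

Working notes on the series.

Three compounds of the shared core carry a different aryl group on the carbonyl carbon. Compound 1 `O=C(Nc1c(C(O)(C(F)(F)F)C(F)(F)F)ccc2ccccc12)c1ccccc1Cl` gives in an assay on LtK cells with ATP-sensitive inward rectifier potassium channel 11 (Homo sapiens) as the target (on this read-out higher numbers stand for an effect only at larger amounts of compound and lower numbers for an effect already at smaller amounts), a value of 2040 nM. Compound 2 `O=C(Nc1c(C(O)(C(F)(F)F)C(F)(F)F)ccc2ccccc12)c1cccc(C(F)(F)F)c1` gives in this assay a value of 84 nM. Compound 3 `O=C(Nc1c(C(O)(C(F)(F)F)C(F)(F)F)ccc2ccccc12)c1ccc(Cl)cc1` gives in this assay a value of 570 nM, which places compound 3 second highest of the three numbers, nearer to compound 1 than to compound 2. The measured steps among them are a 24-fold lower number from compound 1 to compound 2 (1.39 log units; beyond the scatter), a 3.6-fold lower number from compound 1 to compound 3 (0.55 log units; beyond the scatter) and a 6.8-fold higher number from compound 2 to compound 3 (0.83 log units; beyond the scatter).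

Compound 4 `O=C(Nc1c(C(O)(C(F)(F)F)C(F)(F)F)ccc2ccccc12)c1cccnc1` is not yet measured. Its change from compound 3 is pyridin-3-yl in place of 4-chlorophenyl on a carbonyl carbon. Going by the values given here, no measured step removes a chlorine or introduces a ring nitrogen, so none bears on this change directly; the steps of a 3.6-fold lower number from compound 1 to compound 3 (0.55 log units; beyond the scatter) and a 6.8-fold higher number from compound 2 to compound 3 (0.83 log units; beyond the scatter) show only that altering the aryl group on the carbonyl carbon moves the numbers by modest amounts. For compound 4 a step of a 2.6-fold higher number from compound 3 to compound 4 (0.42 log units; beyond the scatter) is therefore expected, toward a higher number, with wide uncertainty. The estimate for compound 4 in this assay is 1500 nM, within a range of 400 nM to 6000 nM.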

Compound 4, half-maximal effective concentration: 60 nM
For compound 4 the middle estimate is 25-fold (1.40 log units) above the measured one; the measured number lies below the stated range.
By their numbers in this assay, from the lowest: compounds 4 and 2 (each within the scatter of the next); then compound 3; then compound 1.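

In this assay the aryl group on the carbonyl carbon need not be a carbon-only ring: pyridin-3-yl, with one hetero atom and one hydrogen-bond acceptor, gives a 9.5-fold lower number from compound 3 to compound 4 (0.98 log units; beyond the scatter) and a 34-fold lower number from compound 1 to compound 4 (1.53 log units; beyond the scatter), both beyond the scatter. With a 1.4-fold lower number from compound 2 to compound 4 (0.15 log units; within the scatter), pyridin-3-yl and 3-(trifluoromethyl)phenyl cannot be told apart here, so among these compounds a low number does not require a substituent on the ring, which the substituted rings of compound 1, compound 2 and compound 3 could not show. No measurement at hand says what lies behind these steps.

From the compounds shown here alone, it stays open whether the step from the 4-chlorophenyl compound reflects the entry of the ring nitrogen or the loss of the chlorine, a separation that plain phenyl on the same carbonyl carbon would provide. Also open, going by these compounds, is how pyridin-2-yl, pyridin-4-yl, or a pyridine ring carrying an amine or a carboxylic acid would read in this assay.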